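Extending the Ether Chain from Compound 3 to Compound 4

A few compounds are considered here, and "the series" means these few. Any claim that something is new, unique, unknown or untested is made for them only; others in the source may bear on it.

Going by the values given here, compound 3 `CCOc1ccc2c(NCCN(C)C)ccnc2c1` gives 3490 nM in a functional assay on NCI-H1650 cells (Homo sapiens) for cytotoxicity, read by MTT assay, with a stated time of 48 h (a higher number here means a weaker inhibitor, a lower number a stronger inhibitor), the highest of the three numbers so far. Compound 1 `CCCCCCOc1ccc2c(Cl)ccnc2c1` gives 2080 nM, a gap within the scatter, while compound 2 `C=CCOc1ccc2c(NCCN(C)C)ccnc2c1` gives 930 nM. Among the compounds with values here, the one step at hand, a 3.8-fold higher number from compound 2 to compound 3 (0.57 log units; beyond the scatter), concerns a different change. Compound 4 `CCCCCCOc1ccc2c(NCCN(C)C)ccnc2c1` differs from compound 3 by butyl in place of hydrogen on a saturated chain carbon, two bonds along the chain from an oxygen on an aromatic ring. Within the data shown here, no measured step tests this lengthening directly; the only guide is compound 1, which carries the same hexyloxy chain and gives 2080 nM, a number within the scatter of compound 3. A step within the scatter is therefore expected for compound 4, a 1.7-fold lower number from compound 3 to compound 4 (0.24 log units; within the scatter). Compound 4 is estimated at 2000 nM, between 700 nM and 6000 nM.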

Compound 4, half-maximal inhibitory concentration: 930 nM
The estimate for compound 4 lay 2.2-fold (0.33 log units) above the measured number; the range from low to high includes it.
By their numbers in this assay, from the lowest: compounds 2 and 4 (each within the scatter of the next); then compounds 1 and 3 (each within the scatter of the next).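

In this assay, going from ethoxy to hexyloxy gives a 3.8-fold lower number from compound 3 to compound 4 (0.57 log units; beyond the scatter), the first sign that chain length at this place matters when the (2-(dimethylamino)ethyl)amino group is present. The hexyloxy chain and the vinyl-ended chain of compound 2 show no change at the digits printed from compound 2 to compound 4 (within the scatter), leaving the ethoxy of compound 3 apart from both. With hexyloxy held fixed, (2-(dimethylamino)ethyl)amino in place of chloro gives a 2.2-fold lower number from compound 1 to compound 4 (0.35 log units; beyond the scatter). Nothing measured here offers a reason for these steps. Going by these compounds, how butoxy or the longer octyloxy chain would read at this place remains open.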